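Swapping 4-iodophenyl for 3,5-difluorophenyl on a shared core

The source may hold more compounds than are shown below. What is called first, only, known or untested is meant among the compounds shown, and "the series" means these compounds.

In a functional assay on SGC-7901 cells (Homo sapiens) for inhibition, read by MTT assay, with a stated time of 48 h (on this read-out lower numbers stand for stronger inhibition and higher numbers for weaker inhibition), compound 1 (`Cc1nnsc1CO/N=C/c1c(C)nn(C)c1Oc1ccc(I)cc1`) gives > 50000 nM as a limit of the assay and not a number. Compound 3 (`Cc1nnsc1CO/N=C/c1c(C)nn(C)c1Oc1ccc(C(C)(C)C)cc1`) gives > 50000 nM as a limit too. Compound 1 therefore stands at the limit of > 50000 nM in this assay, at which 2 of the 3 values shown sit, and has no number of its own. Only compound 2 (`Cc1nnsc1CO/N=C/c1c(C)nn(C)c1Oc1ccc(OC(F)(F)F)cc1`) gives a number, 11500 nM in this series.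

Compound 4 (`Cc1nnsc1CO/N=C/c1c(C)nn(C)c1Oc1cc(F)cc(F)c1`) differs from compound 1 by 3,5-difluorophenyl in place of 4-iodophenyl on an oxygen on an aromatic ring in a single swap: 3,5-difluorophenyl in place of 4-iodophenyl on an oxygen on an aromatic ring. For the measured compounds named here, no measured step makes this swap, so the evidence is indirect. Trifluoromethoxy in place of iodo on an aromatic carbon gave an at least 4.3-fold lower number from compound 1 to compound 2 (0.63 log units; beyond the scatter) while tert-butyl in place of trifluoromethoxy gave an at least 4.3-fold higher number from compound 2 to compound 3 (0.63 log units; beyond the scatter) and tert-butyl in place of iodo gave a step that the two limits leave unreadable from compound 1 to compound 3 as well. Only the first of these is a readable drop from compound 1, and the second shows that a new group can lead back to the limit.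

The estimated step is an at least 1.6-fold lower number from compound 1 to compound 4 (0.22 log units; that floor lies within the scatter) and is expected to be modest, towards lower numbers. In this assay compound 4 is estimated at 30000 nM with an expected range from 10000 nM to 70000 nM.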

Compound 4, half-maximal inhibitory concentration: 9410 nM
Estimate against measurement, compound 4: 3.2-fold (0.50 log units) above; the whole stated range lies above it.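

Setting 3,5-difluorophenyl in place of 4-iodophenyl on an oxygen on an aromatic ring gives an at least 5.3-fold lower number from compound 1 to compound 4 (0.72 log units; beyond the scatter) in this assay. Until now, trifluoromethoxy was the only change shown to give a number rather than a limit, so compound 4 shows that this position also accepts a different aryl group carrying two fluorines, while compound 3 shows that not every change does. The value of compound 1 is a limit, so the step gives only a floor, and its full size remains unknown: the limit of > 50000 nM in this assay, at which 2 of the 4 values shown sit.

On these data alone, whether a phenyl with no substituent, a monofluorophenyl, or a phenyl bearing an amine or a carboxylic acid would also give a number stays open. The compounds shown also do not separate the effect of the two fluorines from the loss of the iodine.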